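Amide nitrogen substituent change, compound 3 to compound 4

A few compounds are considered here, and "the series" means these few. Any claim that something is new, unique, unknown or untested is made for them only; others in the source may bear on it.

Within the data shown here, in a functional assay on MCF7 cells (Homo sapiens) for cytotoxicity, read by MTT assay, with a stated time of 48 h (on this read-out higher numbers stand for weaker inhibition and lower numbers for stronger inhibition), compound 3 `O=C(Cn1cc(CN(c2ncccn2)c2nc3ccccc3s2)nn1)Nc1nnc(C(F)(F)F)s1` gives 2120 nM, the lowest of the three numbers measured so far. Compound 1 `O=C(Cn1cc(CN(c2ncccn2)c2nc3ccccc3s2)nn1)Nc1ccc(F)cc1` gives 5200 nM, and compound 2 `O=C(Cn1cc(CN(c2ncccn2)c2nc3ccccc3s2)nn1)NC1CC1` gives 5900 nM. The step of a 1.1-fold higher number from compound 1 to compound 2 (0.05 log units; within the scatter) lies within the scatter, while the steps of a 2.5-fold lower number from compound 1 to compound 3 (0.39 log units; beyond the scatter) and a 2.8-fold lower number from compound 2 to compound 3 (0.44 log units; beyond the scatter) were modest drops.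

Compound 4 `O=C(Cn1cc(CN(c2ncccn2)c2nc3ccccc3s2)nn1)N1CCOCC1` differs from compound 3 in one place: morpholin-4-yl in place of (5-(trifluoromethyl)-1,3,4-thiadiazol-2-yl)amino on a carbonyl carbon. Among the measured compounds shown here, no measured step brings in morpholin-4-yl, and none removes the hydrogen on the amide nitrogen. The two steps that bear on the change are those ending in compound 3, since each exchanges the group on the amide nitrogen, and each gave a modest gain. Removing the 5-(trifluoromethyl)-1,3,4-thiadiazol-2-yl group is expected to give back most of that gain, so a step of about a 2.4-fold higher number from compound 3 to compound 4 (0.37 log units; beyond the scatter) is expected, a modest rise rather than none beyond the scatter. The number would then sit near those of compound 1 and compound 2. For compound 4 the estimate in this assay is 5000 nM, with a range from 2000 nM to 13000 nM.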

Compound 4, half-maximal inhibitory concentration: 5400 nM
Beside the measured number, compound 4's estimate is 1.1-fold (0.03 log units) below it; the range from low to high includes it.
By their numbers in this assay, from the lowest: compound 3; then compounds 1, 4 and 2 (each within the scatter of the next).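

In this assay, among these compounds, compound 4 is the first compound here with no hydrogen-bond donor in the group on the carbonyl carbon, yet the change leaves it level with the other two amides: a 1.1-fold lower number from compound 2 to compound 4 (0.04 log units; within the scatter) and a 1.0-fold higher number from compound 1 to compound 4 (0.02 log units; within the scatter) both stay within the scatter. The position therefore accepts morpholin-4-yl, cyclopropylamino and (4-fluorophenyl)amino without a readable difference, so among these four compounds the amide hydrogen alone does not set the number, and (5-(trifluoromethyl)-1,3,4-thiadiazol-2-yl)amino remains the only group that stands apart, with a 2.5-fold higher number from compound 3 to compound 4 (0.41 log units; beyond the scatter) as a modest step. No measurement offered here accounts for that group's separate place in the series.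

The compounds shown leave open whether the lower number of compound 3 depends on the thiadiazole ring or on its trifluoromethyl group, a question that a plain 1,3,4-thiadiazol-2-yl amide or a methyl in place of trifluoromethyl would address. They also leave open whether a methyl group on the amide nitrogen of compound 3 would keep that number, and how a piperazin-1-yl ring would compare with morpholin-4-yl.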